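The compounds below may be only part of what the source reports. "The series", "measured", "known", "first", "only" and "open" are said of these compounds alone.

Of the compounds shown here, two from this series have been measured in a functional assay on KB cells (Homo sapiens) for cytotoxicity; a higher number here means that more compound is needed for the effect, a lower number that less compound is needed: compound 1 `COc1c(C)c(OC(C)=O)c(C(C)=O)c(OC(C)=O)c1Cc1c(OC(C)=O)c(CC(OC(C)=O)C(C)(C)OC(C)=O)c(OC(C)=O)c(C(C)=O)c1OC(C)=O`, which gives 22.5 ug/mL, and compound 2 `CCCC(=O)c1c(OC(C)=O)c(Cc2c(OC)c(C)c(OC(C)=O)c(C(C)=O)c2OC(C)=O)c(OC(C)=O)c2c1OC(C)(C)C(OC(C)=O)C2`, which gives 2.8 ug/mL. Compound 2 thus has the lower of the two numbers, and its gap to compound 1 lies beyond the scatter. Compound 3 `COc1c(C)c(OC(C)=O)c(C(C)=O)c(OC(C)=O)c1Cc1c(OC(C)=O)c2c(c(C(=O)C(C)C)c1OC(C)=O)OC(C)(C)C(OC(C)=O)C2` has the same atoms as compound 2, joined differently (isopropyl in place of propyl on a carbonyl carbon). Among the measured compounds shown here, no step between measured compounds shows what this change does, so compound 3 is expected to stay close to compound 2, a step of a 1.3-fold higher number from compound 2 to compound 3 (0.10 log units; within the scatter) not clearly beyond the scatter. Compound 3 is estimated at 3.5 ug/mL, within 1.5 ug/mL to 8 ug/mL.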

Compound 3, concentration for half-maximal effect: 4.5 ug/mL
For compound 3 the middle estimate is 1.3-fold (0.11 log units) below the measured one, and the stated range covers the measured number.
By their numbers in this assay, from the lowest: compounds 2 and 3 (each within the scatter of the next); then compound 1.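

In this assay, among the compounds shown here, isopropyl in place of propyl on a carbonyl carbon gives a 1.6-fold higher number from compound 2 to compound 3 (0.21 log units; within the scatter) and provides the first direct reading of a change at this position. The assay therefore does not separate these two chains of equal heavy-atom count, joined differently on the same carbonyl carbon. Nothing available bears on why they read alike. On these data alone, what remains open is whether a longer chain, a phenyl ring or an amine on this carbonyl carbon would move the number beyond the scatter. A single step also cannot show whether the same change would read alike elsewhere on the core.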